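This account rests on a few compounds, and the source may have more. Where it says the series, first, only, none or still open, it means among the compounds named here.

Compound 3, with the structure `Cc1ccc(/C=C2/N=C(c3ccccc3)N(C(=O)c3ccc(Cl)cc3)NC2=O)cc1`, gives 100 mg/kg in a functional assay on the whole organism (strain albino) with Mus musculus as the target, with a stated time of 4 h (a lower number here means that less compound is needed, a higher number that more compound is needed for the effect), the lowest of the three numbers recorded. Compound 1 `COc1ccc(/C=C2/N=C(c3ccccc3)N(C(=O)c3ccc(Cl)cc3)NC2=O)cc1` gives 300 mg/kg in this assay, and compound 2 `O=C1NN(C(=O)c2ccc(Cl)cc2)C(c2ccccc2)=N/C1=C/c1ccccc1` gives 300 mg/kg. The step from compound 1 to compound 2 shows no change at the digits printed from compound 1 to compound 2 (within the scatter), whereas a 3.0-fold lower number from compound 1 to compound 3 (0.48 log units; beyond the scatter) and a 3.0-fold lower number from compound 2 to compound 3 (0.48 log units; beyond the scatter) both mark a modest gain when methyl is introduced.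

Compound 4 `Cc1ccc(/C=C2/N=C(c3ccccc3)N(C(=O)c3ccc(C)cc3)NC2=O)cc1` differs from compound 3 in one place: methyl in place of chloro on an aromatic carbon. None of the three measured steps touches the (4-chlorophenyl)carbonyl portion; all three concern the substituent on the other aromatic ring, so they bear only loosely on this change. Among the measured compounds shown here, with no direct precedent, a step of modest size in either direction in this assay cannot be ruled out, but the expectation is that the number stays close to that of compound 3.

For compound 4 the estimated value in this assay is 100 mg/kg, within a range of 50 mg/kg to 300 mg/kg, which means an expected step of no change at the digits printed from compound 3 to compound 4 (within the scatter).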

Compound 4, dose for half-maximal effect: 30 mg/kg
For compound 4 the middle estimate is 3.3-fold (0.52 log units) above the measured one, and the stated range ends above it.
By their numbers in this assay, from the lowest: compound 4; then compound 3; then compounds 1 and 2 (each within the scatter of the next).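

In this assay, the (4-chlorophenyl)carbonyl portion proves not to be a silent part of the series: replacing chloro with methyl on this ring gives a 3.3-fold lower number from compound 3 to compound 4 (0.52 log units; beyond the scatter). Among the compounds shown here, all the earlier steps lay on the other aromatic ring, where methyl in place of hydrogen gave a 3.0-fold lower number from compound 2 to compound 3 (0.48 log units; beyond the scatter), so compound 4 shows that a change at either aromatic position can move the number beyond the scatter. Nothing shown here gives a measured reason for the step.

The compounds shown leave open whether it is the methyl group itself that matters on this ring, since hydrogen, methoxy, an ethyl chain or an amine at the same place cannot be compared with it. As far as these compounds go, it also remains open whether the step from chloro to methyl would carry over to compounds with hydrogen or methoxy on the other ring.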